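Notes on a 4-bromophenyl analogue of compound 2

A few compounds are considered here, and "the series" means these few. Any claim that something is new, unique, unknown or untested is made for them only; others in the source may bear on it.

Values so far in a functional assay on B16 cells (Mus musculus) for cytotoxicity, read by CCK-8 assay, with a stated time of 24 h; on this read-out lower numbers stand for stronger inhibition and higher numbers for weaker inhibition
- compound 1 `COc1ccccc1Oc1c(N)nc(-c2cccc(C)c2)nc1Cl` gives 13100 nM
- compound 2 `COc1ccc(-c2nc(N)c(Oc3ccccc3OC)c(Cl)n2)cc1` gives 47800 nM
- compound 3 `COc1ccccc1Oc1c(N)nc(-c2cccc(Cl)c2)nc1Cl` gives 17900 nM

Compound 2 at 47800 nM has the highest number of the three, and its gaps to the other two lie beyond the scatter. Compound 4 `COc1ccccc1Oc1c(N)nc(-c2ccc(Br)cc2)nc1Cl` departs from it by bromo in place of methoxy on an aromatic carbon, which is bromo in place of methoxy on an aromatic carbon, para to a large group. Among the measured compounds shown here, no measured step makes this exact change. The closest guide is a 2.7-fold lower number from compound 2 to compound 3 (0.43 log units; beyond the scatter), a modest change of 4-methoxyphenyl to 3-chlorophenyl. The change of 3-methylphenyl to 4-methoxyphenyl in a 3.6-fold higher number from compound 1 to compound 2 (0.56 log units; beyond the scatter) is also modest and points the same way. Against this, a 1.4-fold higher number from compound 1 to compound 3 (0.14 log units; within the scatter) separates nothing. Both modest steps also move the substituent, which the present change does not, so a modest step to a lower number is expected in this assay, with some doubt. The expected step is a 2.3-fold lower number from compound 2 to compound 4 (0.36 log units; beyond the scatter). Compound 4 is estimated at 21000 nM, within a range of 9000 nM to 48000 nM.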

Compound 4, half-maximal inhibitory concentration: 4440 nM
Beside the measured number, compound 4's estimate is 4.7-fold (0.67 log units) above it; the whole stated range lies above it.
By their numbers in this assay, from the lowest: compound 4; then compounds 1 and 3 (each within the scatter of the next); then compound 2.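

In this assay, among the compounds shown here, the change of 4-methoxyphenyl to 4-bromophenyl gives an 11-fold lower number from compound 2 to compound 4 (1.03 log units; beyond the scatter) and is the first step that leaves the substituent in place, showing that the group para to a large group can by itself carry a large step. Compound 4 also separates from the two analogues with a substituent elsewhere on the ring, through a 4.0-fold lower number from compound 3 to compound 4 (0.61 log units; beyond the scatter) and a 3.0-fold lower number from compound 1 to compound 4 (0.47 log units; beyond the scatter), although each of these steps changes both the group and its place. No measurement at hand explains the size of the step from methoxy to bromo.

Still open, on these data alone, is whether the lower number goes with bromo specifically or with any group other than methoxy in this place. Chloro, methyl, an amine or a carboxylic acid in the same place would test this, and 3-bromophenyl would separate the group from its place.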